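This account rests on a few compounds, and the source may have more. Where it says the series, first, only, none or still open, it means among the compounds named here.

Of the compounds shown here, three that share one bridged core have been measured in an ADME assay on L6 cells (Rattus norvegicus) for cytotoxicity, read by resazurin assay, with a stated time of 72 h; on this read-out higher numbers stand for weaker inhibition and lower numbers for stronger inhibition. Compound 1 `CN1CCN(CC(=O)OC2CC3(N(C)C)CC(c4ccccc4)C2C(c2ccccc2)C3)CC1` gives 39900 nM, compound 2 `CN1CCN(CCC(=O)NC2CC3(N(C)C)CC(c4ccccc4)C2C(c2ccccc2)C3)CC1` gives 95000 nM, and compound 3 `CN1CCN(CC(=O)NC2CC3(N(C)C)CC(c4ccccc4)C2C(c2ccccc2)C3)CC1` gives 66200 nM. On these numbers compound 3 stands second highest of the three, with compound 2 as its nearest neighbour and compound 1 as its furthest, and both gaps lie within the scatter. Two single-change steps connect them. The step of a 1.7-fold higher number from compound 1 to compound 3 (0.22 log units; within the scatter) puts an amino link in place of an oxy link at the saturated ring carbon. The step of a 1.4-fold lower number from compound 2 to compound 3 (0.16 log units; within the scatter) puts 4-methylpiperazin-1-yl in place of (4-methylpiperazin-1-yl)methyl on the chain carbon bound to the carbonyl. Neither moved the read-out beyond the scatter.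

Compound 4 `CN(C)C12CC(OC(=O)CN3CCCCC3)C(C(c3ccccc3)C1)C(c1ccccc1)C2` is not yet measured. It differs from compound 3 by (((piperidin-1-yl)methyl)carbonyl)oxy in place of (((4-methylpiperazin-1-yl)methyl)carbonyl)amino on a saturated ring carbon. Going by the values given here, this change reverses the amino-for-oxy exchange of the first step and also puts a piperidin-1-yl ring where a 4-methylpiperazin-1-yl ring stood, an exchange for which no measured pair exists. Because a 1.7-fold higher number from compound 1 to compound 3 (0.22 log units; within the scatter) stayed within the scatter, the link exchange is expected to shift the number little, while the ring exchange adds uncertainty. Compound 4 is therefore estimated at 40000 nM, within a range from 13000 nM to 120000 nM, and the expected step of a 1.7-fold lower number from compound 3 to compound 4 (0.22 log units; within the scatter) is not expected to exceed the scatter.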

Compound 4, half-maximal inhibitory concentration: 29300 nM
The estimate for compound 4 lay 1.4-fold (0.14 log units) above the measured number, and the stated range covers the measured number.
By their numbers in this assay, from the lowest: compounds 4, 1, 3 and 2 (each within the scatter of the next, the first and the last beyond it).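

In this assay, going by these compounds alone, the step of a 2.3-fold lower number from compound 3 to compound 4 (0.35 log units; beyond the scatter) is the first to pass the scatter, though only modestly, and it makes two exchanges at once on the saturated ring carbon: the oxy link replaces the amino link, and piperidin-1-yl replaces 4-methylpiperazin-1-yl. Within the data shown here, the step of a 1.4-fold lower number from compound 1 to compound 4 (0.13 log units; within the scatter) gives the first measured pair for the ring exchange alone, and it stays within the scatter. The step of a 1.7-fold higher number from compound 1 to compound 3 (0.22 log units; within the scatter) likewise stays within the scatter for the link exchange alone, so only the two exchanges taken together pass it, and the data cannot assign that step to either one.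

No measurement shown here explains the step beyond the scatter. The compounds shown leave open how an (((piperidin-1-yl)methyl)carbonyl)amino group would read at this position, which would complete the set of link and ring pairs, and whether a morpholin-4-yl ring in the same place would read like the piperidin-1-yl ring or the 4-methylpiperazin-1-yl ring.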